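The source may report more compounds than this note shows. Statements on the series, on what has been measured and on what is new or still open speak of the compounds shown alone.

Measured so far:
compound 1 `Cc1nnc(SCC(=O)N/N=c2/scc(-c3ccc(F)cc3)n2-c2ccccc2)s1`; in a functional assay on C6 cells (Rattus norvegicus) for cytotoxicity, read by MTT assay, with a stated time of 24 h, tested at 100 ug/mL (on this read-out higher numbers stand for a weaker effect at the one concentration tested and lower numbers for a stronger effect), compound 1 gives 34.9%.
compound 2 `Cc1ccc(-c2cs/c(=N/NC(=O)CSc3ncccn3)n2-c2ccccc2)cc1`; compound 2 gives 45.9%.
compound 3 `O=C(CSc1ncccn1)N/N=c1/scc(-c2ccc(F)cc2)n1-c1ccccc1`; compound 3 gives 53.4%.

Compound 4 `Cc1ccc(-c2cs/c(=N/NC(=O)CSc3nnc(C)s3)n2-c2ccccc2)cc1` has not yet been measured. It is built from compound 2 by one change: 5-methyl-1,3,4-thiadiazol-2-yl in place of pyrimidin-2-yl on a sulfur. The same change has already been made once among the measured compounds, from compound 3 to compound 1: 5-methyl-1,3,4-thiadiazol-2-yl in place of pyrimidin-2-yl on a sulfur. There it gave a number 18.5 percentage points lower from compound 3 to compound 1 (beyond the scatter), a move toward a stronger effect on the cells at the single concentration tested. The surroundings of the change read the same in both pairs, so this is the same change, not merely the same kind of change. The two starting cores differ elsewhere: methyl in place of fluoro on an aromatic carbon. That difference shows as a number 7.5 percentage points higher from compound 2 to compound 3 (within the scatter), so compound 2 and compound 3 cannot be told apart on this read-out. For compound 4 the expected step is a number 15.9 percentage points lower from compound 2 to compound 4 (beyond the scatter), resting on the measured step of a number 18.5 percentage points lower from compound 3 to compound 1 (beyond the scatter). Compound 4 is therefore estimated at 30%, with the likely range running from 18% to 42%.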

Compound 4, a percentage reported as activity, at one concentration (the size of the read-out at that concentration, not a potency): 31.5%
Compound 4: middle estimate off by 1.5 percentage points, on the low side; the range from low to high includes it.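

Putting 5-methyl-1,3,4-thiadiazol-2-yl in place of pyrimidin-2-yl on the sulfur gives a number 14.4 percentage points lower from compound 2 to compound 4 (beyond the scatter) in this assay, and the change carries over to the methyl-bearing compounds with much the same size as in the fluoro-bearing pair: the same change on two cores in this assay, a number 18.5 percentage points lower (beyond the scatter) from compound 3 to compound 1 and a number 14.4 percentage points lower (beyond the scatter) from compound 2 to compound 4, 4.1 percentage points apart, within the scatter of two such steps. Methyl in place of fluoro on the aromatic carbon gives a number 3.4 percentage points lower from compound 1 to compound 4 (within the scatter), so that swap cannot be read on this pair, nor on the earlier one: the same change on two cores in this assay, a number 7.5 percentage points higher (within the scatter) from compound 2 to compound 3 and a number 3.4 percentage points higher (within the scatter) from compound 4 to compound 1, 4.1 percentage points apart, within the scatter of two such steps. Among the compounds shown here, this is only two matched pairs that differ by one small group, read at a single concentration, so it shows neither a potency nor that the change would carry over to a more different core.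

The compounds shown leave open whether the methyl on the thiadiazole matters, which a plain 1,3,4-thiadiazol-2-yl group would test. They also leave open how a chloro or methoxy group would read in place of the fluoro or methyl.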